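Swapping methyl for fluoro on a benzyloxy arm

The source may report more compounds than this note shows. Statements on the series, on what has been measured and on what is new or still open speak of the compounds shown alone.

Measured so far:
compound 1 `Cc1ccc(COc2ccc(C(=O)NC(=S)Nc3ccc(C)c(-c4nc5ccccc5[nH]4)c3)cc2)cc1` gives 4980 nM
compound 2 `Cc1ccc(NC(=S)NC(=O)c2ccc(OCc3ccc(F)cc3)cc2)cc1-c1nc2ccccc2[nH]1` gives 2810 nM
compound 3 `Cc1ccc(COc2ccc(C(=O)NC(=O)Nc3ccc(Cl)c(-c4nc5ccccc5[nH]4)c3)cc2)cc1` gives 3860 nM

All three were tested in a functional assay on MGC-803 cells (Homo sapiens) for inhibition, read by MTT assay, with a stated time of 48 h; on this read-out higher numbers stand for weaker inhibition and lower numbers for stronger inhibition. Compound 1 and compound 2 differ in a single place, (fluoro in place of methyl on an aromatic carbon), and this change gave a 1.8-fold lower number from compound 1 to compound 2 (0.25 log units; within the scatter). Compound 3 carries the same arm as compound 1, but the difference between the two cores is not broken down here. Compound 4 `O=C(NC(=O)c1ccc(OCc2ccc(F)cc2)cc1)Nc1ccc(Cl)c(-c2nc3ccccc3[nH]2)c1` has not been measured yet; it relates to compound 3 by the same change, (fluoro in place of methyl on an aromatic carbon), at a place described in the same words. Because compound 3 gives 3860 nM in this assay and the earlier step was a 1.8-fold lower number from compound 1 to compound 2 (0.25 log units; within the scatter), the expected step is a 1.8-fold lower number from compound 3 to compound 4 (0.24 log units; within the scatter). Compound 4 is therefore estimated at 2200 nM. The range expected for compound 4 runs from 1200 nM to 5000 nM.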

Compound 4, half-maximal inhibitory concentration: 61 nM
For compound 4 the middle estimate is 36-fold (1.56 log units) above the measured one; the measured number lies below the stated range.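

In this assay, putting fluoro in place of methyl on the benzyloxy arm gives a 63-fold lower number from compound 3 to compound 4 (1.80 log units; beyond the scatter), a large gain in inhibition on this core. The size of the step therefore did not carry over from one core to the other: the same change on two cores in this assay, a 1.8-fold lower number (0.25 log units; within the scatter) from compound 1 to compound 2 and a 63-fold lower number (1.80 log units; beyond the scatter) from compound 3 to compound 4, 36-fold (1.55 log units) apart, beyond the scatter of two such steps. This shows that the effect of the swap depends on the core it sits on, but not which difference between the two cores lies behind the gap.

As far as these compounds go, whether the large step would hold on a core that differs from that of compound 3 in only one place stays open. So does what a methoxy group or an amine would do at the same spot on the arm.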